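Aryl group changes on the shared core: working notes

A few compounds are considered here, and "the series" means these few. Any claim that something is new, unique, unknown or untested is made for them only; others in the source may bear on it.

- compound 1 `CC1(C)CCC[C@]2(C)[C@@H](CC[C@@](C)(O)/C=C/c3ccccc3)[C@](C)(O)CC[C@@H]12`: 121 nM
- compound 2 `CC1(C)CCC[C@]2(C)[C@@H](CC[C@@](C)(O)/C=C/c3ccc(Cl)nc3)[C@](C)(O)CC[C@@H]12`: 275 nM

Among the compounds with values here, in a functional assay on PC-3 cells (Homo sapiens) for cytotoxicity, read by MTT assay, with a stated time of 48 h (a higher number here means a weaker inhibitor, a lower number a stronger inhibitor), compound 2 gives 275 nM, the higher of the two numbers so far. Compound 3 `Cc1cccc(C)c1/C=C/[C@](C)(O)CC[C@@H]1[C@@]2(C)CCCC(C)(C)[C@@H]2CC[C@@]1(C)O` differs from it as follows: 2,6-dimethylphenyl in place of 6-chloropyridin-3-yl on a double-bonded chain carbon bound to a double-bonded chain carbon. That is, 2,6-dimethylphenyl stands in place of 6-chloropyridin-3-yl on a double-bonded chain carbon bound to a double-bonded chain carbon. Within the data shown here, only one measured step bears on this, the modest 2.3-fold higher number from compound 1 to compound 2 (0.36 log units; beyond the scatter). Among the measured compounds shown here, no measured compound carries 2,6-dimethylphenyl, so the guide is weak. A modest fall in the number is expected, estimated as a 1.6-fold lower number from compound 2 to compound 3 (0.21 log units; within the scatter) in this assay. The estimate for compound 3 is 170 nM, with a range of 70 nM to 420 nM.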

Compound 3, half-maximal inhibitory concentration: 278 nM
The estimate for compound 3 lay 1.6-fold (0.21 log units) below the measured number, and the stated range covers the measured number.
By their numbers in this assay, from the lowest: compound 1; then compounds 2 and 3 (each within the scatter of the next).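

In this assay, 2,6-dimethylphenyl and 6-chloropyridin-3-yl at this place cannot be told apart (a 1.0-fold higher number from compound 2 to compound 3 (0.00 log units; within the scatter)). Two different replacements of phenyl now stand beyond the scatter from compound 1, so the earlier step is no longer a single case (a 2.3-fold higher number from compound 1 to compound 3 (0.36 log units; beyond the scatter)). Nothing at hand gives a cause for this agreement between the two groups.

On these data alone, whether any aryl group here can give a lower number than phenyl stays open. So does the reading of an amine or a carboxylic acid on the phenyl ring at this place.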